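The compounds below may be only part of what the source reports. "The series", "measured", "known", "first", "only" and "open" are said of these compounds alone.

For the measured compounds named here, in a functional assay on MCF7 cells (Homo sapiens) for inhibition, read by MTT assay, with a stated time of 24 h (on this read-out higher numbers stand for weaker inhibition and lower numbers for stronger inhibition), compound 1 `O=C1CSC(c2c[nH]nc2-c2ccc(F)cc2)N1n1c(S)nnc1COc1ccccc1` gives 30 ug/mL, the lower of the two numbers measured so far. Compound 2 `COc1ccc(-c2n[nH]cc2C2SCC(=O)N2n2c(S)nnc2COc2ccccc2)cc1` gives 85 ug/mL; the step of a 2.8-fold higher number from compound 1 to compound 2 (0.45 log units; beyond the scatter) concerns the fluoro-bearing ring, not the phenoxymethyl arm. Compound 3 `O=C1CSC(c2c[nH]nc2-c2ccc(F)cc2)N1n1c(S)nnc1COc1ccc2ccccc2c1` differs from compound 1 by naphthalen-2-yl in place of phenyl on an oxygen on a saturated carbon. Going by the values given here, no measured step touches the phenoxy group, so nothing measured bears directly on this change; the expectation is therefore no step beyond the scatter, no change at the digits printed from compound 1 to compound 3 (within the scatter). Compound 3 is estimated at 30 ug/mL, with a range from 12 ug/mL to 75 ug/mL.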

Compound 3, half-maximal inhibitory concentration: > 100 ug/mL
Compound 3 gave a limit, no number (the forecaster's own chance of this, stated with the estimate: 5%); at least 3.3-fold (0.52 log units) between middle value and limit.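

For the compounds shown here, replacing phenyl with naphthalen-2-yl on this oxygen gives an at least 3.3-fold higher number from compound 1 to compound 3 (0.52 log units; beyond the scatter) in this assay, so the phenoxy end of the series is not silent, and the one change measured here goes towards weaker inhibition. Compound 3 reads > 100 ug/mL, which is a limit of the assay and not a number. This rests on a single pair, with the fluoro-bearing ring held constant.

Open, as far as these compounds go, is how a methyl or benzyl group on this oxygen would read. Also open, from the compounds shown here alone, is whether a phenyl ring carrying an amine or a carboxylic acid would read like compound 1.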